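The compounds below may be only part of what the source reports. "The series", "measured", "known", "first", "only" and "open" are said of these compounds alone.

In a physicochemical assay for solubility, read by HPLC, in phosphate buffer, measured as kinetic solubility, with a stated time of 1 h, at pH 7.4, tested at 250 uM (on this read-out lower numbers stand for lower solubility and higher numbers for higher solubility), compound 1 `O=C(NCCCCc1ccccc1)n1cc(-c2ccc(F)cc2)oc1=O` gives only a limit, < 1000 nM, so it has no exact position on the scale. Compound 2 `COc1cccc(-c2cn(C(=O)NCCCCc3ccccc3)c(=O)o2)c1` also gives a limit, < 1000 nM. Compound 3 `O=C(NCCCCc1ccccc1)n1cc(-c2cccnc2)oc1=O` gives a limit too, < 1000 nM. All three therefore sit together at the limit of < 1000 nM in this assay, at which 3 of the 3 values shown sit.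

Compound 4 `CN1CCC(c2cc(-c3cn(C(=O)NCCCCc4ccccc4)c(=O)o3)ccc2F)CC1` carries 1-methylpiperidin-4-yl in place of hydrogen on an aromatic carbon of the 4-fluorophenyl ring of compound 1, ortho to the fluoro group and meta to a large group: 1-methylpiperidin-4-yl in place of hydrogen on an aromatic carbon.

The measured steps that bear on this change the same aromatic group, and they offer no size to carry over. Replacing 4-fluorophenyl with 3-methoxyphenyl gives a step that the two limits leave unreadable from compound 1 to compound 2. Replacing it with pyridin-3-yl gives a step that the two limits leave unreadable from compound 1 to compound 3. The expectation therefore rests on the structural change alone and remains loose. An upward move is expected, estimated as an at least 20-fold higher number from compound 1 to compound 4 (1.30 log units; beyond the scatter). For compound 4 the expected value is 20000 nM, with an estimated range of 2000 nM to 150000 nM.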

Compound 4, solubility: 30000 nM
Estimate against measurement, compound 4: 1.5-fold (0.18 log units) below; the measured number falls inside the stated range.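

Going by these compounds alone, putting 1-methylpiperidin-4-yl in place of hydrogen on the aromatic carbon ortho to a fluoro group and meta to a large group yields in this assay an at least 30-fold higher number from compound 1 to compound 4 (1.47 log units; beyond the scatter) as the first step of readable size. The earlier swaps of the aromatic group cannot be read, so this single substitution is the only change shown to move the number clear of the shared limit: the limit of < 1000 nM in this assay, at which 3 of the 4 values shown sit.

The compounds shown leave open whether the step depends on the ring nitrogen, which a cyclohexyl group at the same place would test, or whether an open-chain amine would serve as well. On these data alone, it also remains open whether 1-methylpiperidin-4-yl would give a step of similar size on the pyridin-3-yl ring of compound 3.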